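The source may report more compounds than this note shows. Statements on the series, on what has been measured and on what is new or still open speak of the compounds shown alone.

Compound 3, `COC(C)(C)CCCC(C)C/C=C/C(C)=C/C(=O)OC1CC1`, gives 5.71 in a physicochemical assay for lipophilicity; a higher number here means a more lipophilic compound, a lower number a more polar compound. Among the three compounds measured so far it holds the lowest number, though compound 2, `C=CC(C)OC(=O)/C=C(C)/C=C/CC(C)CCCC(C)(C)OC`, with 5.94 lies within the usual scatter of it; only compound 1, `CCCCOC(=O)/C=C(C)/C=C/CC(C)CCCC(C)(C)OC`, with 6.62 stands clearly apart. The steps between them all concern the group on the oxygen of the ester: a number 0.68 log units lower from compound 1 to compound 2 (beyond the scatter), a number 0.91 log units lower from compound 1 to compound 3 (beyond the scatter), and a number 0.23 log units lower from compound 2 to compound 3 (within the scatter).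

Compound 4, `COC(C)(C)CCCC(C)C/C=C/C(C)=C/C(=O)NC(C)C`, carries a different kind of change. isopropylamino in place of cyclopropyloxy on a carbonyl carbon The measured steps offer only indirect guidance: each swapped one carbon group for another on an oxygen, and none exchanged that oxygen for a nitrogen or brought in a hydrogen-bond donor, so the scale of those steps can only mark how much this part of the shared core has moved the number before.

On that basis a drop is expected, larger than the swaps seen so far. Compound 4 is expected to give about 4.5 in this assay, within roughly 3.8 to 5.3. That estimate means a number 1.21 log units lower from compound 3 to compound 4 (beyond the scatter) is expected.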

Compound 4, partition coefficient: 4.45
Beside the measured number, compound 4's estimate is 0.05 log units above it, and the stated range covers the measured number.
By their numbers in this assay, from the lowest: compound 4; then compounds 3 and 2 (each within the scatter of the next); then compound 1.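

In this assay, the step to isopropylamino on the carbonyl carbon is large whichever ester is the starting point: a number 1.26 log units lower from compound 3 to compound 4 (beyond the scatter) and a number 1.49 log units lower from compound 2 to compound 4 (beyond the scatter) and also a number 2.17 log units lower from compound 1 to compound 4 (beyond the scatter). The earlier compounds shown here varied only the carbon group on the ester oxygen, whereas this change puts a nitrogen on the carbonyl carbon and brings in a hydrogen-bond donor, and the number at this position moves further than in any step among the three esters. Nothing at hand explains why the number falls.

The swap also removes a ring, so compound 4 alone cannot show how much of the step goes with the nitrogen and how much goes with the change from cyclopropyl to isopropyl, a question that cyclopropylamino on the same carbonyl carbon would address directly. Also open, from the compounds shown here alone, is how a dimethylamino group, which has no amide hydrogen, would compare, and how butylamino would stand against the butoxy group of compound 1.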